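The source may report more compounds than this note shows. Statements on the series, on what has been measured and on what is new or still open speak of the compounds shown alone.

Measured in an ADME assay for permeability, using PAMPA, at pH 4; on this read-out lower numbers stand for lower permeability and higher numbers for higher permeability:
Compound 1 `Cc1ccc2[nH]c(C)c(Br)c(=O)c2c1`: 26.4 10^-6 cm/s
Compound 2 `Cc1[nH]c2ccc(Cl)cc2c(=O)c1Br`: 84.5 10^-6 cm/s
Compound 3 `Cc1[nH]c2ccc(F)cc2c(=O)c1Br`: 16.2 10^-6 cm/s

Compound 2 stands highest of these three. The number rises in a 3.2-fold higher number from compound 1 to compound 2 (0.51 log units; beyond the scatter) and falls in a 5.2-fold lower number from compound 2 to compound 3 (0.72 log units; beyond the scatter), while the remaining step is a 1.6-fold lower number from compound 1 to compound 3 (0.21 log units; within the scatter).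

Compound 4 `CCCCC#Cc1c(C)[nH]c2ccc(Cl)cc2c1=O` has not yet been measured in this assay. It keeps the chloro of compound 2 and changes elsewhere: hex-1-yn-1-yl in place of bromo on an aromatic carbon. In words, this is hex-1-yn-1-yl in place of bromo on an aromatic carbon. Among the measured compounds shown here, none of the measured steps touches that carbon. All three exchange methyl, chloro and fluoro on another aromatic carbon, with bromo present throughout, so they serve only as a rough gauge of how far a single exchange can move this read-out among these compounds. The data do not fix a direction. Still, compound 2 tops the set at 84.5 10^-6 cm/s, so a fall looks likelier than a rise, and a modest step of similar size to those seen is expected.

The expected change is a 2.4-fold lower number from compound 2 to compound 4 (0.38 log units; beyond the scatter). For compound 4 the estimated value is 35 10^-6 cm/s, with an expected range from 7 10^-6 cm/s to 150 10^-6 cm/s.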

Compound 4, apparent permeability: 171 10^-6 cm/s
Beside the measured number, compound 4's estimate is 4.9-fold (0.69 log units) below it, outside the stated range (above it).
By their numbers in this assay, from the lowest: compounds 3 and 1 (each within the scatter of the next); then compound 2; then compound 4.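

In this assay, putting hex-1-yn-1-yl in place of bromo on the aromatic carbon ortho to a methyl group gives a 2.0-fold higher number from compound 2 to compound 4 (0.31 log units; beyond the scatter), the first step shown at this carbon. The earlier compounds shown here exchanged only methyl, chloro and fluoro on another aromatic carbon, with bromo present throughout, so this step adds two things: the read-out also responds to a change at this second carbon, and a group of 6 heavy atoms containing a triple bond can replace a single bromine here with the number going up rather than down. Nothing measured here accounts for the rise, and the step alone gives no reason for it.

This single step cannot separate the effect of the triple bond from that of the chain length, and a saturated hexyl chain, a shorter prop-1-yn-1-yl group or an amine at the same carbon would each help to tell these apart. On these data alone, it also remains open whether the same exchange moves the number in the same direction when methyl or fluoro stands in place of the chloro of compound 2.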